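Benzyloxy for methoxy on the oxime: cytotoxicity notes

The source may hold more compounds than are shown below. What is called first, only, known or untested is meant among the compounds shown, and "the series" means these compounds.

Compound 1 `CO/N=c1\[nH]cnc2c1[n+](C/C=C(\C)CC/C=C(/C)CCC=C(C)C)cn2C` and compound 2 `CC(C)=CCC/C(C)=C\CC/C(C)=C/C[n+]1cn(C)c2nc[nH]/c(=N\OCc3ccccc3)c21` share one core; compound 3 `CO/N=c1\[nH]cnc2ncn(C/C=C(\C)CC/C=C(\C)CC/C=C(\C)CCC=C(C)C)c12` and compound 4 `CC(C)=CCC/C(C)=C/CC/C(C)=C/CC/C(C)=C/Cn1cnc2nc[nH]/c(=N\OCc3ccccc3)c21` share another, and the difference between the two cores is not broken down here. In a functional assay on ACHN cells (Homo sapiens) for cytotoxicity (on this read-out higher numbers stand for weaker inhibition and lower numbers for stronger inhibition), compound 1 gives 28700 nM, compound 2 gives 25200 nM and compound 3 gives 18100 nM, all three within the scatter of one another. The change from compound 1 to compound 2 is phenyl in place of hydrogen on a saturated chain carbon bound to an oxygen, and it made a 1.1-fold lower number from compound 1 to compound 2 (0.06 log units; within the scatter). The same change, (phenyl in place of hydrogen on a saturated chain carbon bound to an oxygen), is now applied to compound 3 to give compound 4. The earlier step of a 1.1-fold lower number from compound 1 to compound 2 (0.06 log units; within the scatter) stayed within the scatter. On that basis the step from compound 3 to compound 4 is expected to be about a 1.1-fold lower number from compound 3 to compound 4 (0.03 log units; within the scatter) in this assay. Compound 4 is therefore estimated at 17000 nM, with a range from 8000 nM to 36000 nM.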

Compound 4, half-maximal inhibitory concentration: 27400 nM
The estimate for compound 4 lay 1.6-fold (0.21 log units) below the measured number; low and high end bracket the measured number.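

In this assay, phenyl in place of hydrogen on a saturated chain carbon bound to an oxygen gives a 1.5-fold higher number from compound 3 to compound 4 (0.18 log units; within the scatter). Set beside the same change on the other core, the two steps do not differ: the same change on two cores in this assay, a 1.1-fold lower number (0.06 log units; within the scatter) from compound 1 to compound 2 and a 1.5-fold higher number (0.18 log units; within the scatter) from compound 3 to compound 4, 1.7-fold (0.24 log units) apart, within the scatter of two such steps. The change therefore carries between these two cores without a visible shift on this read-out, but with one pair per core and both steps within the scatter, this shows neither a real effect of the change on either core nor that it would behave alike on a third core.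

Open, going by these compounds, is whether a longer chain or an amine in place of the phenyl would move the number beyond the scatter. Also open, on these data alone, is what the difference between the two cores contributes by itself.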